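Swapping Methyl for Fluoro at the Assay Limit

This account rests on a few compounds, and the source may have more. Where it says the series, first, only, none or still open, it means among the compounds named here.

Measured so far in a functional assay on MCF7 cells (Homo sapiens) for cytotoxicity, read by MTT assay, with a stated time of 48 h; on this read-out lower numbers stand for stronger inhibition and higher numbers for weaker inhibition:
- compound 1 `c1ccc(-c2nnc(COc3ccc(-c4nnco4)cc3)o2)cc1`: > 50000 nM (a limit)
- compound 2 `COc1ccc(-c2nnc(COc3ccc(-c4nnco4)cc3)o2)cc1`: 31200 nM
- compound 3 `Cc1ccc(-c2nnc(COc3ccc(-c4nnco4)cc3)o2)cc1`: > 50000 nM (a limit)

Compound 3 gives only a limit, > 50000 nM, and not a number. Compound 1 also gives only a limit, > 50000 nM. Within the data shown here, compound 2 is the only one with a number, 31200 nM.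

The next compound, compound 4 `Fc1ccc(-c2nnc(COc3ccc(-c4nnco4)cc3)o2)cc1`, carries fluoro in place of methyl on an aromatic carbon, para to a large group: fluoro in place of methyl on an aromatic carbon. Among the measured compounds shown here, no measured compound carries fluoro, so the nearest guides are changes at the same place on the ring. Methoxy in place of hydrogen gave an at least 1.6-fold lower number from compound 1 to compound 2 (0.20 log units; that floor lies within the scatter). Methyl in place of methoxy gave an at least 1.6-fold higher number from compound 2 to compound 3 (0.20 log units; that floor lies within the scatter). Methyl in place of hydrogen gave a step that the two limits leave unreadable from compound 1 to compound 3.

Going by the limit of > 50000 nM in this assay, at which 2 of the 3 values shown sit, compound 4 is expected to stay close to that limit in this assay, with no step beyond the scatter, and it may also report only a limit. The expected change is an at least 1.1-fold lower number from compound 3 to compound 4 (0.04 log units; that floor lies within the scatter). For compound 4 the estimated value is 45000 nM, with an expected range from 20000 nM to 80000 nM.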

Compound 4, half-maximal inhibitory concentration: 35600 nM
Compound 4: the middle estimate sits 1.3-fold (0.10 log units) above what was measured; the range from low to high includes it.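

In this assay, compound 4 joins compound 2 as a second compound with a number rather than a limit, so this place on the ring now has two readable groups. Fluoro in place of hydrogen gives an at least 1.4-fold lower number from compound 1 to compound 4 (0.14 log units; that floor lies within the scatter), and fluoro in place of methyl gives an at least 1.4-fold lower number from compound 3 to compound 4 (0.14 log units; that floor lies within the scatter); the true steps could be larger, but neither floor shows a step beyond the scatter, and both comparisons remain tied to an assay limit: the limit of > 50000 nM in this assay, at which 2 of the 4 values shown sit. Fluoro in place of methoxy gives a 1.1-fold higher number from compound 2 to compound 4 (0.06 log units; within the scatter), so these two groups cannot be told apart here, even though the 4-fluorophenyl and methoxy-bearing compounds differ in the group at this place.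

On these data alone, how far compound 1 and compound 3 really sit from compound 4 stays unknown while those two compounds report only limits. As far as these compounds go, it also remains open whether any other group at this place, such as an amine, a carboxylic acid or a longer chain, can bring the number far below those seen for compound 2 and compound 4.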